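Shifting a Hydroxyl Group Toward a Measurable Result

The source may report more compounds than this note shows. Statements on the series, on what has been measured and on what is new or still open speak of the compounds shown alone.

Of the compounds shown here, three share one core and have been tested in a functional assay on T47D cells (Homo sapiens) for cytotoxicity, read by CCK-8 assay; a lower number here means a stronger inhibitor, a higher number a weaker inhibitor. Compound 1 `Oc1cccc(-c2cc(-c3cccs3)cc(-c3cccc(O)c3)n2)c1` gives 770 nM. Compound 2 `Oc1cccc(-c2cc(-c3ccsc3)cc(-c3cccc(O)c3)n2)c1` gives 1510 nM, and the change a 2.0-fold higher number from compound 1 to compound 2 (0.29 log units; within the scatter) is therefore too small to count as a real difference. Compound 3 `Oc1cccc(-c2cc(-c3ccoc3)cc(-c3ccccc3O)n2)c1` is different: in this assay it reaches only the limit > 50000 nM, which is a boundary of the measurement rather than a number, as noted in the limit of > 50000 nM in this assay, at which 1 of the 3 values shown sits. It is the one of the three that carries a 2-hydroxyphenyl group instead of a second 3-hydroxyphenyl group.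

Compound 4 `Oc1cccc(-c2cc(-c3ccoc3)cc(-c3cccc(O)c3)n2)c1` is not yet measured. It differs from compound 3 by 3-hydroxyphenyl in place of 2-hydroxyphenyl on an aromatic carbon. Among the measured compounds shown here, no measured step concerns this particular exchange; the only measured step swaps one five-membered ring for another and stays within the scatter. What compounds 1 and 2 do show is that two 3-hydroxyphenyl groups on this core, with a small heteroaryl ring, give a number rather than a limit. On that basis compound 4 is expected to give a measurable value, estimated at 3000 nM, with a likely range from 800 nM to 15000 nM. The expected step of an at least 16-fold lower number from compound 3 to compound 4 (1.22 log units; beyond the scatter) is a move from a limit to a number and is an estimate only.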

Compound 4, half-maximal inhibitory concentration: 2590 nM
The estimate for compound 4 lay 1.2-fold (0.06 log units) above the measured number, and the stated range covers the measured number.
By their numbers in this assay, from the lowest: compounds 1, 2 and 4 (each within the scatter of the next, the first and the last beyond it). At a limit, above all of these: compound 3.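

Among the compounds shown here, compound 3 and compound 4 have the same atoms, joined differently, so the only change is where the hydroxyl sits on the ring next to the ring nitrogen, and in this assay this exchange gives an at least 19-fold lower number from compound 3 to compound 4 (1.28 log units; beyond the scatter). For the compounds shown here, this is the first sign that this position on the shared core responds strongly to the placement of a single hydroxyl, and the figure gives only the minimum size of the step, with compound 3 at a limit: the limit of > 50000 nM in this assay, at which 1 of the 4 values shown sits. The exchanges of the five-membered ring are much smaller by comparison, with furan-3-yl in place of thiophen-3-yl giving a 1.7-fold higher number from compound 2 to compound 4 (0.23 log units; within the scatter) and furan-3-yl in place of thiophen-2-yl giving a 3.4-fold higher number from compound 1 to compound 4 (0.53 log units; beyond the scatter).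

From the compounds shown here alone, whether moving the hydroxyl would have the same large effect with a thiophen-2-yl or thiophen-3-yl group on the core remains open. The compounds shown also do not tell what would happen if an amine or a carboxylic acid took the place of the hydroxyl on the 3-hydroxyphenyl ring.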